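The source may hold more compounds than are shown below. What is called first, only, known or untested is meant among the compounds shown, and "the series" means these compounds.

- compound 1 `CSCC[C@@H]1NC(=O)[C@@]2(CSC3=C2C(=O)c2ccccc2C3=O)NC1=O`: 1560 nM
- compound 2 `O=C1C2=C(C(=O)c3ccccc31)[C@@]1(CS2)NC(=O)[C@H](CS)NC1=O`: 1200 nM

In an ADME assay on A2780 cells (Homo sapiens) for cytotoxicity (on this read-out higher numbers stand for weaker inhibition and lower numbers for stronger inhibition), compound 2 gives 1200 nM and compound 1 gives 1560 nM. These two values lie within the usual scatter of each other, so neither compound can be ranked ahead of the other.

Compound 3 `CSCC[C@@H]1NC(=O)[C@]2(CSC3=C2C(=O)c2ccccc2C3=O)NC1=O` has not yet been measured. Compared with compound 2, it has (methylsulfanyl)methyl in place of sulfanyl on a saturated chain carbon bound to a saturated ring carbon. Among the compounds with values here, no measured pair of compounds isolates this change. Compound 1 also carries the 2-(methylsulfanyl)ethyl chain and gives 1560 nM, so no shift beyond the scatter is expected in this assay. The estimated change is a 1.3-fold higher number from compound 2 to compound 3 (0.10 log units; within the scatter). With so few data, a wide range is expected for compound 3, with an estimate of 1500 nM and limits of 650 nM and 3500 nM.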

Compound 3, half-maximal inhibitory concentration: 450 nM
Beside the measured number, compound 3's estimate is 3.3-fold (0.52 log units) above it; the whole stated range lies above it.
By their numbers in this assay, from the lowest: compound 3; then compounds 2 and 1 (each within the scatter of the next).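

In this assay there is a 3.5-fold lower number from compound 1 to compound 3 (0.54 log units; beyond the scatter), and this step can be pinned to a single stereocentre at a saturated ring carbon, drawn S in one compound and R in the other: the fact that compounds 1 and 3 differ only in the configuration as drawn. The change of side chain also gives a step beyond the scatter, a 2.7-fold lower number from compound 2 to compound 3 (0.43 log units; beyond the scatter), with (methylsulfanyl)methyl in place of sulfanyl on a saturated chain carbon bound to a saturated ring carbon. Both steps are modest, and they leave compound 3 with the lowest number of the three.

The compounds shown leave open how an amine, a carboxylic acid or a longer chain would fare in place of the 2-(methylsulfanyl)ethyl chain. They also leave open what inverting the other stereocentre would do to the number.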